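A few compounds are considered here, and "the series" means these few. Any claim that something is new, unique, unknown or untested is made for them only; others in the source may bear on it.

Two compounds share a core that carries a trimethoxyphenyl group and a methoxyphenyl group, and differ only in the aryl group on the amide-type nitrogen. Compound 1 `COc1ccc(NC(=O)c2nc(-c3cc(OC)c(OC)c(OC)c3)n(-c3ccc(OC)cc3)n2)cc1` bears a 4-methoxyphenyl there, and in a functional assay on the whole organism for inhibition, with Rattus norvegicus as the target, read by paw edema, with stated times of 30 min and 1 h, at a dose of 0.28 mmol/kg by the oral route (on this read-out higher numbers stand for more inhibition at the one dose given (going by the name of the read-out) and lower numbers for less inhibition), compound 1 gives 39%. Compound 2 `COc1ccc(-n2nc(C(=O)Nc3ccccc3OC)nc2-c2cc(OC)c(OC)c(OC)c2)cc1` carries a 2-methoxyphenyl in that place, and in this assay compound 2 gives 52%. For the measured compounds named here, the single measured step is a number 13 percentage points higher from compound 1 to compound 2 (beyond the scatter), so compound 2 stands highest of the two numbers, with compound 1 the nearest and lower by a margin beyond the scatter.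

Compound 3 `COc1ccc(-n2nc(C(=O)Nc3cccc(F)c3)nc2-c2cc(OC)c(OC)c(OC)c2)cc1` is the unmeasured analogue. Its change from compound 2 is 3-fluorophenyl in place of 2-methoxyphenyl on an amide-type nitrogen. Going by the values given here, no measured step matches this change: the one step in hand moves a methoxy group from one place on the aryl ring to another, whereas here the methoxy group leaves altogether and a fluorine enters. That step was modest in size, so the expectation is that the change to compound 3 also stays modest and could go either way, giving an expected step of a number 7 percentage points lower from compound 2 to compound 3 (within the scatter). For compound 3 the estimate in this assay is 45%, with a range from 28% to 62%.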

Compound 3, a percentage reported as inhibition, in the whole organism at one dose (the size of the read-out at that dose, not a potency): 48%
Estimate against measurement, compound 3: 3 percentage points below, within the range that was stated.
By their numbers in this assay, from the lowest: compounds 1, 3 and 2 (each within the scatter of the next, the first and the last beyond it).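

On the amide-type nitrogen, the aryl ring in this assay need not carry a methoxy group at all: exchanging 2-methoxyphenyl for 3-fluorophenyl removes the oxygen and the one hydrogen-bond acceptor counted in the group, and it gives a number 4 percentage points lower from compound 2 to compound 3 (within the scatter). The comparison with the other methoxy compound gives a number 9 percentage points higher from compound 1 to compound 3 (within the scatter), so compound 3 cannot be separated from either compound 1 or compound 2, even though those two lie beyond the scatter of each other, and the earlier picture of a single step between two methoxy isomers now gains a fluorine-bearing compound that falls inside that gap without being ranked against either end. No measurement presented here bears on why this position responds as it does.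

The three compounds all keep a substituted phenyl ring on this nitrogen, so they leave open how the read-out would respond to an unsubstituted phenyl, or to a saturated group such as a cyclohexyl or a longer alkyl chain in place of the ring. They also leave open what a carboxylic acid or an amine on that ring would do to the inhibition seen at this one dose.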